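The compounds below may be only part of what the source reports. "The series", "measured", "known", "first", "only" and "open" are said of these compounds alone.

Measured compounds:
- compound 1, `COc1cccc(OC)c1OCCNCCOc1ccccc1OCc1ccccc1`, in a functional assay on thoracic aorta for antagonist activity at Alpha-1D adrenergic receptor (Rattus norvegicus) (on this read-out lower numbers stand for lower potency and higher numbers for higher potency (the scale is a negative logarithm)), compound 1 gives 9.37
- compound 2, `COc1cccc(OC)c1OCCNCCOc1ccccc1OCc1ccccc1Cl`: compound 2 gives 8.59
- compound 3, `COc1cccc(OC)c1OCCNCCOc1ccccc1OCc1cccc(C)c1`: compound 3 gives 8.85

Compound 3 stands second highest of the three. Its nearest neighbour is compound 2, and the gap between them, a number 0.26 log units higher from compound 2 to compound 3 (within the scatter), is within the usual scatter, so the two cannot be told apart. Compound 1 is the furthest away and clearly higher, as a number 0.52 log units lower from compound 1 to compound 3 (beyond the scatter) shows.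

Compound 4, `COc1cccc(OC)c1OCCNCCOc1ccccc1OCc1ccccc1[N+](=O)[O-]`, differs from compound 3 in one place: 2-nitrophenyl in place of 3-methylphenyl on a saturated chain carbon bound to an oxygen on an aromatic ring. Among the compounds with values here, two measured steps bear on this. Adding a chloro to the benzyl ring gave a number 0.78 log units lower from compound 1 to compound 2 (beyond the scatter), and adding a methyl gave a number 0.52 log units lower from compound 1 to compound 3 (beyond the scatter); both substituted benzyl groups sit below the bare one. Going by these compounds, there is no measurement of a nitro group in this position, so its effect is unknown. The expectation is therefore that compound 4 lands near compounds 2 and 3, with an estimated step of a number 0.35 log units lower from compound 3 to compound 4 (beyond the scatter), small and within the scatter. For compound 4 the expected value in this assay is 8.5, estimated to lie between 7.9 and 9.1.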

Compound 4, negative logarithm of the antagonist equilibrium constant: 8.95
Estimate against measurement, compound 4: 0.45 log units below, and the stated range covers the measured number.
By their numbers in this assay, from the lowest: compounds 2, 3 and 4 (each within the scatter of the next, the first and the last beyond it); then compound 1.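

In this assay, the 2-nitrobenzyl group also falls short of the unsubstituted benzyl group (a number 0.42 log units lower from compound 1 to compound 4 (beyond the scatter)), so all three substituted benzyl groups shown here sit below compound 1, and none goes against this. The new compound also shows that the choice of substituent can matter at this position: nitro in place of chloro gives a modest gain (a number 0.36 log units higher from compound 2 to compound 4 (beyond the scatter)), whereas 2-nitrobenzyl and 3-methylbenzyl cannot be told apart (a number 0.10 log units higher from compound 3 to compound 4 (within the scatter)), even though they differ in both their atoms and their substituent. No evidence is available to explain these differences. Going by these compounds, it remains open whether an amine or a carboxylic acid on the benzyl ring would also fall below compound 1. On these data alone, it also remains open whether any substituent on this ring could match the unsubstituted benzyl group.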